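A few compounds are considered here, and "the series" means these few. Any claim that something is new, unique, unknown or untested is made for them only; others in the source may bear on it.

Measured so far, in an assay on CHO-TREX cells for antagonist activity at transient receptor potential cation channel subfamily A member 1 (Homo sapiens), read by FLIPR and calcium flux, with a stated time of 10 min; on this read-out lower numbers stand for stronger inhibition and higher numbers for weaker inhibition:
Compound 1 `CCc1cc2[nH]ncc2cc1-c1ccccc1C(F)(F)F` gives 50 nM.
Compound 2 `FC(F)(F)c1ccccc1-c1cc2cn[nH]c2cc1C1CC1` gives 61 nM.
Compound 3 `COc1cc2[nH]ncc2cc1-c1ccccc1C(F)(F)F` gives 26 nM.

Going by the values given here, compound 3 shows the lowest number of the three, but its gap to compound 1 is within the scatter, as a 1.9-fold lower number from compound 1 to compound 3 (0.28 log units; within the scatter) tells; only the step of a 2.3-fold lower number from compound 2 to compound 3 (0.37 log units; beyond the scatter) is beyond the scatter, and modest. Compound 4 `CCOc1cc2[nH]ncc2cc1-c1ccccc1C(F)(F)F` differs from compound 3 by methyl in place of hydrogen on a saturated chain carbon bound to an oxygen on an aromatic ring. Among the compounds with values here, none of the measured steps alters this chain; they replace the whole substituent on the aromatic carbon, and all were small. By that reasoning the change to compound 4 is expected to be small as well, a 1.3-fold higher number from compound 3 to compound 4 (0.13 log units; within the scatter), without a step beyond the scatter. The estimate for compound 4 in this assay is 35 nM, between 12 nM and 100 nM.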

Compound 4, half-maximal inhibitory concentration: 39 nM
The estimate for compound 4 lay 1.1-fold (0.05 log units) below the measured number; measured number inside the range.
By their numbers in this assay, from the lowest: compounds 3, 4, 1 and 2 (each within the scatter of the next, the first and the last beyond it).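

Replacing methoxy with ethoxy changes the chain itself rather than swapping the whole substituent, and a 1.5-fold higher number from compound 3 to compound 4 (0.18 log units; within the scatter) shows that in this assay this added methyl leaves the number within the scatter. Ethoxy also stays within the scatter of both carbon-linked groups, as a 1.3-fold lower number from compound 1 to compound 4 (0.11 log units; within the scatter) and a 1.6-fold lower number from compound 2 to compound 4 (0.19 log units; within the scatter) show, even though compound 3 and compound 2 are separated beyond it. Nothing available explains the size of these steps. Still open, from the compounds shown here alone, is whether a longer chain on the oxygen, or an amine on this aromatic carbon, would shift the number beyond the scatter.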